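Lengthening the Amide Chain in a Melatonin Receptor Series

This account rests on a few compounds, and the source may have more. Where it says the series, first, only, none or still open, it means among the compounds named here.

Measured so far:
compound 1 `CCC(=O)NCCCc1cccc2c1C[C@@H](CCCCc1ccccc1)O2`, 1 nM
compound 2 `O=C(NC[C@@H]1C[C@H]1c1cccc2c1C[C@@H](CCCCc1ccccc1)O2)C1CC1`, 1 nM

In an assay on NIH3T3 cells for binding affinity to melatonin receptor type 1A (Homo sapiens) (on this read-out lower numbers stand for stronger inhibition and higher numbers for weaker inhibition), compound 1 gives 1 nM. Compound 2, which carries a different linker and a different acyl group on the shared core, gives 1 nM in this assay. Compound 1 thus stands level with compound 2 at the digits shown, the two values falling within the usual scatter of each other, so neither can be placed above the other.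

Compound 3 `CCCC(=O)NCCCc1cccc2c1C[C@@H](CCCCc1ccccc1)O2` has not yet been measured in this assay. It differs from compound 1 by methyl in place of hydrogen on a saturated chain carbon, two bonds along the chain from a carbonyl carbon, that is, propanoyl to propylcarbonyl on the amide. Among the compounds with values here, no step between two measured compounds isolates such a change, so nothing in the data so far shows it to matter. Compound 3 is therefore expected to come out at about 1 nM, within 0.4 nM to 2.5 nM. The expected step of no change at the digits printed from compound 1 to compound 3 (within the scatter) is estimated to stay within the scatter, in no clear direction.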

Compound 3, inhibition constant: 2 nM
The estimate for compound 3 lay 2.0-fold (0.30 log units) below the measured number; the range from low to high includes it.
By their numbers in this assay, from the lowest: compounds 1, 2 and 3 (each within the scatter of the next).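

In this assay, within the data shown here, methyl in place of hydrogen on a saturated chain carbon, two bonds along the chain from a carbonyl carbon, gives a 2.0-fold higher number from compound 1 to compound 3 (0.30 log units; within the scatter) and is the first step here that isolates a single change. On this read-out, propanoyl and propylcarbonyl on the amide therefore cannot be told apart, so this position takes the added methyl without a step beyond the scatter. No independent evidence bears on this result.

The compounds shown leave open whether this holds only for one added methyl or also for a longer chain, such as pentanoyl on the amide, or for a branched chain. They also leave open what an amine or a hydroxyl group at the same chain carbon would give in this assay and whether the same change would read alike on the linker of compound 2.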